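Moving a carboxylic acid onto the outer ring

A few compounds are considered here, and "the series" means these few. Any claim that something is new, unique, unknown or untested is made for them only; others in the source may bear on it.

Compound 3 `COc1cccc(Oc2ccc([C@H]3S[C@@H](C)C(=O)Nc4c3c(C)nn4-c3ccccc3C)cc2)c1` gives 1700 nM in an assay on isolated protein for agonist activity at Bile acid receptor (Homo sapiens), read by AlphaScreen, with a stated time of 30 min (on this read-out higher numbers stand for an effect only at larger amounts of compound and lower numbers for an effect already at smaller amounts), the lowest of the two numbers available; compound 2 `CCOc1cccc(-c2ccc([C@H]3S[C@@H](C)C(=O)Nc4c3c(C)nn4-c3ccccc3C)cc2)c1` gives 3500 nM, and the step of a 2.1-fold lower number from compound 2 to compound 3 (0.31 log units; beyond the scatter) lies beyond the scatter. Compound 1 `Cc1ccccc1-n1nc(C)c2c1NC(=O)[C@H](C)S[C@@H]2c1ccc(Oc2ccccc2C(=O)O)cc1`, which also bears a carboxylic acid, is reported as "not active" (no number reported) in this assay. Compound 4 `Cc1ccccc1-n1nc(C)c2c1NC(=O)[C@H](C)S[C@@H]2c1ccc(Oc2ccc(C(=O)O)cc2)cc1` differs from compound 3 by 4-carboxyphenyl in place of 3-methoxyphenyl on an oxygen on an aromatic ring. Among the measured compounds shown here, no measured step places a carboxylic acid at this position, so the only guide is compound 1, whose result "not active" (no number reported) points toward a weaker effect once an acid is present. The step to compound 4 is therefore expected to be a 3.5-fold higher number from compound 3 to compound 4 (0.55 log units; beyond the scatter), toward a higher number. Compound 4 is estimated at 6000 nM, with a range from 1500 nM to 25000 nM.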

Compound 4, half-maximal effective concentration: "not active" (no number reported)
No number was reported for compound 4; there is nothing to compare the estimate with.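

Like compound 1, compound 4 is reported as "not active" (no number reported) in this assay, so no step from compound 3 can be read, and no evidence here bears on the result. The compounds shown leave open whether any carboxylic acid on the outer ring can give a number on this read-out.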